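Branching the Sulfonyl Chain in a Receptor Antagonist Series

This account rests on a few compounds, and the source may have more. Where it says the series, first, only, none or still open, it means among the compounds named here.

Compound 2, `CCCCS(=O)(=O)Nc1ccc(CN2CCC(CNC(=O)c3cccc4c3OCCO4)CC2)cc1`, gives 8 in a functional assay on HEK293 cells for antagonist activity at 5-hydroxytryptamine receptor 4 (Homo sapiens); a lower number here means a less potent compound, a higher number a more potent compound, by a factor of ten per unit of this negative logarithm. Compound 1, `CS(=O)(=O)Nc1ccc(CN2CCC(CNC(=O)c3cccc4c3OCCO4)CC2)cc1`, gives 8.3 in this assay, and the two numbers lie within the scatter of each other, so compound 2 stands level with compound 1 on the numbers shown. Among the measured compounds shown here, the one measured step between them, a number 0.30 log units lower from compound 1 to compound 2 (within the scatter), shows that putting a propyl group onto the carbon bound to the sulfonyl sulfur, in place of hydrogen, left the read-out essentially where it was.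

Compound 3, `CC(C)CS(=O)(=O)Nc1ccc(CN2CCC(CNC(=O)c3cccc4c3OCCO4)CC2)cc1`, differs from compound 2 by isopropyl in place of propyl on a saturated chain carbon bound to a sulfonyl sulfur. For the measured compounds named here, no measured pair shows the effect of branching this chain; the step from compound 1 to compound 2 bears on it only in that the chain itself, whether present or absent, changes little. On that basis the step from compound 2 to compound 3 is expected to stay within the scatter, no change at the digits printed from compound 2 to compound 3 (within the scatter). Compound 3 is therefore estimated at 8 in this assay, with a range from 7.6 to 8.4.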

Compound 3, negative logarithm of the antagonist equilibrium constant in the 5-hydroxytryptamine receptor 4 assay: 8
Beside the measured number, compound 3's estimate shows no gap at the digits printed, within the range that was stated.
By their numbers in the 5-hydroxytryptamine receptor 4 assay, from the lowest: compounds 2, 3 and 1 (each within the scatter of the next).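

Among the compounds shown here, in the 5-hydroxytryptamine receptor 4 assay, compound 2 gives 8 and compound 3 gives 8; this is the first measured pair on branching at this position, and isopropyl and propyl on a saturated chain carbon bound to a sulfonyl sulfur stand level (no change at the digits printed from compound 2 to compound 3 (within the scatter)). Compound 3 also stands level with compound 1, which carries no such chain (a number 0.30 log units lower from compound 1 to compound 3 (within the scatter)), so the branched and unbranched chains both lie within the scatter of that shorter compound. In a physicochemical assay for lipophilicity, at pH 7.4 (a higher number here means a more lipophilic compound, a lower number a more polar compound), compound 2 gives 1.8 and compound 3 gives 1.8, so the same exchange of propyl for isopropyl does not separate the two compounds either (no change at the digits printed from compound 2 to compound 3 (within the scatter)), and no available evidence accounts for these results.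

The compounds shown leave open whether a much longer chain, a phenyl ring, an amine or a carboxylic acid at this place would stay level with these three in the 5-hydroxytryptamine receptor 4 assay. They also leave open whether the level readings extend to more heavily branched or ring-bearing groups, such as tert-butyl or cyclohexyl, in either the 5-hydroxytryptamine receptor 4 assay or the physicochemical assay.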